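The compounds below may be only part of what the source reports. "The series", "measured", "known", "first", "only" and "open" are said of these compounds alone.

Compound 1 `CC[C@H](C)[C@H](N)CN(C(=O)[C@@H]1C[C@H]1c1ccc(OC)cc1)c1ccc(-c2ccccc2)cc1`: > 25000 nM
Compound 2 `CC[C@H](C)[C@H](N)CN(C(=O)[C@@H]1C[C@H]1c1ccccc1F)c1ccc(-c2ccccc2)cc1`: 650 nM

In a functional assay for agonist activity at G protein-coupled receptor 88 (Homo sapiens), read by HTRF and cAMP accumulation (on this read-out lower numbers stand for an effect already at smaller amounts and higher numbers for an effect only at larger amounts of compound), compound 1 gives only a limit, > 25000 nM, and not a number. Going by the values given here, compound 2 gives 650 nM in this assay, the only number among the values shown. The other value, that of compound 1, is a limit. Among the compounds with values here, the single measured step, an at least 38-fold lower number from compound 1 to compound 2 (1.58 log units; beyond the scatter), rests on the limit (the limit of > 25000 nM in this assay, at which 1 of the 2 values shown sits), so only its lower bound is known. Compound 3 `CC[C@H](C)[C@H](N)CN(C(=O)[C@@H]1C[C@H]1c1cccc(C)c1)c1ccc(-c2ccccc2)cc1` differs from compound 2 by 3-methylphenyl in place of 2-fluorophenyl on a saturated ring carbon. Within the data shown here, the one measured step also exchanges the aryl group on the saturated ring carbon, but between different groups, so it offers no direct guide to a methyl-bearing ring, and a step beyond the scatter in either direction remains possible. A modest loss is expected, a 3.1-fold higher number from compound 2 to compound 3 (0.49 log units; beyond the scatter). Compound 3 is therefore expected to give about 2000 nM in this assay, within 400 nM to 15000 nM.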

Compound 3, half-maximal effective concentration: 1200 nM
Compound 3: the middle estimate sits 1.7-fold (0.22 log units) above what was measured; the measured number falls inside the stated range.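

In this assay, swapping 2-fluorophenyl for 3-methylphenyl gives a 1.8-fold higher number from compound 2 to compound 3 (0.27 log units; within the scatter), so these two aryl groups on the saturated ring carbon cannot be told apart. The position therefore accepts more than one aryl group, and 2-fluorophenyl is not alone in giving a measured number. Against 4-methoxyphenyl, 3-methylphenyl gives an at least 20-fold lower number from compound 1 to compound 3 (1.31 log units; beyond the scatter), a second large gap, and only its lower bound is known because it rests on the limit of compound 1: the limit of > 25000 nM in this assay, at which 1 of the 3 values shown sits.

On these data alone, it remains open whether the methoxy group itself or the place it occupies on the ring sets compound 1 apart, a question that 3-methoxyphenyl and 4-methylphenyl groups would address. Also open, as far as these compounds go, is how an unsubstituted phenyl ring, or one carrying an amine, would compare.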